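The compounds below may be only part of what the source reports. "The series", "measured", "known", "first", "only" and "open" are said of these compounds alone.

Measured so far in an ADME assay on H9c2 cells (Rattus norvegicus) for cytotoxicity; a higher number here means a weaker inhibitor, a lower number a stronger inhibitor:
- compound 1 `O=C(Nc1nc2cc(Cl)ccc2s1)C1CC1`: > 50000 nM (a limit)
- compound 2 `O=C(Nc1nc2ccc(OC(F)(F)F)cc2s1)C1CC1`: 5000 nM
- compound 3 `O=C(Nc1nc2ccc(Cl)cc2s1)C1CCC1`: > 50000 nM (a limit)

Compound 3 stands at > 50000 nM, which is a limit of the assay and not a number. Compound 1 gives > 50000 nM, which is also a limit. Among the compounds with values here, compound 2 gives 5000 nM, the one numerical reading in the set. Within the data shown here, no pair of measured compounds differs in one place only, so the series offers no direct measured step as a guide.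

The next compound is compound 4 `O=C(CCO)Nc1nc2ccc(Cl)cc2s1`. Here 2-hydroxyethyl takes the place of cyclobutyl on a carbonyl carbon: 2-hydroxyethyl in place of cyclobutyl on a carbonyl carbon.

No step beyond the usual scatter is expected in this assay, so no direction is assigned. This expectation rests on compound 3, whose reading of > 50000 nM is a limit, and on (the limit of > 50000 nM in this assay, at which 2 of the 3 values shown sit). Compound 2, at 5000 nM, keeps a numerical reading possible, so the expected range extends downward. The estimated step is a number no higher from compound 3 to compound 4 (the limit leaves the size open). For compound 4 the expected value is 50000 nM, with an estimated range of 15000 nM to 100000 nM.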

Compound 4, half-maximal inhibitory concentration: > 50000 nM
Compound 4 was reported as a limit; the forecaster's own chance of this, stated with the estimate: 70%; the middle value sits exactly at the limit.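

In this assay, compound 3 and compound 4 are both reported as limits of the assay, and no step can be read between them. Left open is whether 2-hydroxyethyl in place of cyclobutyl on a carbonyl carbon changes the reading at all, with the series crowded at one value: the limit of > 50000 nM in this assay, at which 3 of the 4 values shown sit.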